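A few compounds are considered here, and "the series" means these few. Any claim that something is new, unique, unknown or untested is made for them only; others in the source may bear on it.

Compound 1 `O=C(NCc1cc(Cl)ccc1-n1cnnn1)[C@@H]1[C@@H]2C[C@@H]2CN1C(=O)[C@H](O)Cc1ccccn1` is the starting point. In a functional assay on a cell-free system (plasma, Homo sapiens), with a stated time of 3 min (on this read-out higher numbers stand for weaker inhibition and lower numbers for stronger inhibition), compound 1 gives 1700 nM. Compound 2 `COC(C)(C)[C@@H](O)C(=O)N1C[C@H]2C[C@H]2[C@H]1C(=O)NCc1cc(Cl)ccc1-n1cnnn1` differs from compound 1 in a single place, (1-methoxy-1-methylethyl in place of (pyridin-2-yl)methyl on a saturated chain carbon bound to a carbonyl carbon and an oxygen on a saturated carbon); in this assay compound 2 gives 1000 nM, and the step is a 1.7-fold lower number from compound 1 to compound 2 (0.23 log units; within the scatter). Compound 3 `O=C(NCc1cc(Cl)ccc1-n1cnnn1)[C@@H]1C[C@@H]2C[C@@H]2N1C(=O)[C@H](O)Cc1ccccn1` has the same atoms as compound 1 joined differently, so its core is not the same; the difference between the two cores is not broken down here. In this assay compound 3 gives 1000 nM, a value level with that of compound 2 at the digits shown. Compound 4 `COC(C)(C)[C@@H](O)C(=O)N1[C@H](C(=O)NCc2cc(Cl)ccc2-n2cnnn2)C[C@@H]2C[C@@H]21` carries the same change on the core of compound 3: 1-methoxy-1-methylethyl in place of (pyridin-2-yl)methyl on a saturated chain carbon bound to a carbonyl carbon and an oxygen on a saturated carbon. The place is worded identically in both cases, so this is the same change, not merely the same kind. For compound 4 the expected step is a 1.5-fold lower number from compound 3 to compound 4 (0.19 log units; within the scatter), set beside the measured 1.7-fold lower number from compound 1 to compound 2 (0.23 log units; within the scatter), because the earlier step was a 1.7-fold lower number from compound 1 to compound 2 (0.23 log units; within the scatter) and nothing in these three compounds suggests the second core would answer differently. Compound 4 is therefore expected to give about 650 nM, with a likely range from 300 nM to 1400 nM.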

Compound 4, half-maximal inhibitory concentration: 1000 nM
Compound 4: the middle estimate sits 1.5-fold (0.19 log units) below what was measured; measured number inside the range.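

In this assay, putting 1-methoxy-1-methylethyl in place of (pyridin-2-yl)methyl on the core of compound 3 gives no change at the digits printed from compound 3 to compound 4 (within the scatter). Set beside the same change on the core of compound 1, the two steps cannot be told apart: the same change on two cores in this assay, a 1.7-fold lower number (0.23 log units; within the scatter) from compound 1 to compound 2 and no change at the digits printed (within the scatter) from compound 3 to compound 4, 1.7-fold (0.23 log units) apart, within the scatter of two such steps. This shows that the swap, which removes the aromatic ring, leaves the number within the scatter on both cores, but it does not show that the swap has a real effect on potency, nor that it would behave alike on any core beyond these two.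

Among these compounds, with no step here rising above the scatter, these compounds cannot reveal whether a change with a clear effect would also carry from one core to the other. As far as these compounds go, it remains open whether an amine, a carboxylic acid or a longer chain in this same place would move the number on either core, and whether it would do so by the same amount on both.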